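A smaller fluorinated ring in place of the carbon cage

The compounds below may be only part of what the source reports. "The series", "measured", "known", "first", "only" and "open" are said of these compounds alone.

Compound 1 `FC(F)Oc1ccc(-c2nnc3cncc(OCCc4ccccc4)n23)cc1` gives 6.3 ug/mL in a physicochemical assay for solubility, read by nephelometry, in phosphate buffer, measured as kinetic solubility, with a stated time of 30 min, at pH 6.5; a lower number here means a less soluble compound, a higher number a more soluble compound.
Compound 2 `FC(F)Oc1ccc(-c2nnc3cncc(OCCC45C6C7C8C6C4C8C75)n23)cc1` gives < 1.6 ug/mL in this assay, a limit of the assay rather than a number.

Compound 2 therefore stands at the low end of the two results shown, known only to lie under the mark of the limit of < 1.6 ug/mL in this assay, at which 1 of the 2 values shown sits. Compound 3 `FC(F)Oc1ccc(-c2nnc3cncc(OCC45CC(C(F)F)(C4)C5)n23)cc1` differs from compound 2 by a group of 8 heavy atoms (6 carbon, 2 fluorine; 2 four-membered non-aromatic rings of carbon only) in place of a group of 9 heavy atoms (9 carbon; 5 four-membered non-aromatic rings of carbon only), on a saturated chain carbon bound to an oxygen on an aromatic ring. For the measured compounds named here, only one measured step bears on this: an at least 3.9-fold lower number from compound 1 to compound 2 (0.59 log units; beyond the scatter), in which the same cage of four-membered rings entered and the solubility fell. The change to compound 3 removes that cage again, although what enters is not the group compound 1 carries, so a partial recovery is expected rather than a full return. Compound 3 is expected to give 3 ug/mL, within 1.2 ug/mL to 8 ug/mL. For compound 3 the estimated step is an at least 1.8-fold higher number from compound 2 to compound 3 (0.27 log units; that floor lies within the scatter), with a real chance that the assay again reports only a limit.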

Compound 3, solubility: 6.3 ug/mL
The estimate for compound 3 lay 2.1-fold (0.32 log units) below the measured number, within the range that was stated.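

In this assay, putting the fluorine-bearing group with 2 four-membered non-aromatic rings of carbon only in place of the cage with 5 such rings gives an at least 3.9-fold higher number from compound 2 to compound 3 (0.59 log units; beyond the scatter). That size is only a floor, because compound 2 carries a limit of the assay rather than a number: the limit of < 1.6 ug/mL in this assay, at which 1 of the 3 values shown sits. Set against the group with one six-membered aromatic ring of carbon only, the same fluorine-bearing group gives no change at the digits printed from compound 1 to compound 3 (within the scatter), so at this place, on a saturated chain carbon bound to an oxygen on an aromatic ring, these two different groups read alike.

On these data alone, whether the fluorine atoms or the smaller ring group matter more stays open, a question that a methyl group in place of the difluoromethyl group could address. As far as these compounds go, how an amine or a carboxylic acid at this place would read in this assay also stays open.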